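A Third Methoxy Group on Two Related Cores

A few compounds are considered here, and "the series" means these few. Any claim that something is new, unique, unknown or untested is made for them only; others in the source may bear on it.

Measured so far:
compound 1, `COc1ccc(N(C)c2nc(Cl)nc3c2ncn3Cc2cc(OC)cc(OC)c2)cc1` — > 100000 nM in a functional assay on SH-SY5Y cells (Homo sapiens) for antiproliferative activity, read by MTT assay, with a stated time of 48 h (on this read-out higher numbers stand for weaker inhibition of growth and lower numbers for stronger inhibition of growth), a limit of the assay
compound 2, `COc1ccc(N(C)c2nc(Cl)nc3c2ncn3Cc2cc(OC)c(OC)c(OC)c2)cc1` — 3000 nM
compound 3, `COc1cc(Cn2cnc3c(Cl)ncnc32)cc(OC)c1` — > 100000 nM, a limit of the assay

Compound 1 and compound 2 differ in one place, (methoxy in place of hydrogen on an aromatic carbon). That change gave an at least 33-fold lower number from compound 1 to compound 2 (1.52 log units; beyond the scatter). Compound 1 sits at a limit of this assay, and so does compound 3; this is the limit of > 100000 nM in this assay, at which 2 of the 3 values shown sit, so for compound 1 the true starting point of that step is not known, and the step is a lower bound.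

Compound 3 carries a different core from compound 1; how the two cores differ is not broken down here. Compound 4, `COc1cc(Cn2cnc3c(Cl)ncnc32)cc(OC)c1OC`, stands to compound 3 as compound 2 stands to compound 1: the difference is methoxy in place of hydrogen on an aromatic carbon, and its surroundings are described word for word as for the earlier pair, so it is the same change on another core.

Among the measured compounds shown here, whether the gain seen from compound 1 to compound 2 carries over to the smaller core of compound 3 cannot be read from the measured compounds alone, since only one step is known. The expectation rests on it nonetheless: compound 4 is expected to show an at least 5.0-fold lower number from compound 3 to compound 4 (0.69 log units; beyond the scatter), because the same change produced an at least 33-fold lower number from compound 1 to compound 2 (1.52 log units; beyond the scatter). With that, compound 4 is estimated at 20000 nM, with a range from 3000 nM to 100000 nM, and a fair chance that this assay again reports only a limit.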

Compound 4, concentration for 50% growth inhibition: > 100000 nM
Compound 4: only a limit was reported; the forecaster's own chance of this, stated with the estimate: 40%; at least 5.0-fold (0.69 log units) between middle value and limit.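

In this assay compound 4 gives > 100000 nM as a limit of the assay. The size of the step from compound 3 to compound 4 cannot be read, because both compounds sit at the same limit: the limit of > 100000 nM in this assay, at which 3 of the 4 values shown sit.

Going by these compounds, what stays open is whether the added methoxy group lowers the number at all on the core of compound 3, where both values shown are limits.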